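The compounds below may be only part of what the source reports. "The series", "measured", "known", "first", "only" and "open" are said of these compounds alone.

Working notes on the series, measured in a functional assay on HL-60 cells (Homo sapiens) for cytotoxicity, with a stated time of 24 h (on this read-out higher numbers stand for lower toxicity in this test and lower numbers for higher toxicity in this test), so far:
- compound 1 `O=C1/C(=C/c2ccccc2)CCC/C1=C\c1ccccc1[N+](=O)[O-]` gives 3700 nM
- compound 2 `COc1ccc(/C=C2\CCC/C(=C\c3ccccc3[N+](=O)[O-])C2=O)cc1` gives 26000 nM
- compound 3 `O=C1/C(=C/c2ccccc2)CCC/C1=C\c1cccc([N+](=O)[O-])c1` gives 3000 nM

Compound 3 stands level with compound 1, within the scatter, and both lie clearly lower than compound 2.

Compound 4 `CN(C)c1ccc(/C=C2\CCC/C(=C\c3cccc([N+](=O)[O-])c3)C2=O)cc1` carries one change from compound 3: dimethylamino in place of hydrogen on an aromatic carbon.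

Going by the values given here, one measured step bears on it, the methoxy replacement a 7.0-fold higher number from compound 1 to compound 2 (0.85 log units; beyond the scatter), which is modest and beyond the scatter. With this single precedent, a modest rise is expected in this assay, its size uncertain.

The expected step is a 3.7-fold higher number from compound 3 to compound 4 (0.56 log units; beyond the scatter) as an estimate only.

For compound 4 the estimated value is 11000 nM, with an expected range from 2500 nM to 40000 nM.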

Compound 4, half-maximal cytotoxic concentration: 30000 nM
Compound 4: the middle estimate sits 2.7-fold (0.44 log units) below what was measured, within the range that was stated.
By their numbers in this assay, from the lowest: compounds 3 and 1 (each within the scatter of the next); then compounds 2 and 4 (each within the scatter of the next).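

In this assay, phenyl to 4-(dimethylamino)phenyl gives a 10-fold higher number from compound 3 to compound 4 (1.00 log units; beyond the scatter) and so shows a rise with a second group at this place, not only with methoxy. The rise also appears with the nitro group placed as in compound 3, not only as in compound 1. No measured evidence bears on the reason for this rise.

As far as these compounds go, whether any group at this place lowers the number, for instance fluorine or a carboxylic acid, stays open. From the compounds shown here alone, how methoxy and dimethylamino compare on one and the same core also stays open.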